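This account rests on a few compounds, and the source may have more. Where it says the series, first, only, none or still open, it means among the compounds named here.

Series notes. Compound 1 `Nc1nc(NCc2cccs2)nc2sc(-c3ccco3)nc12` in an assay on CHO cells for displacement of a labelled ligand from adenosine receptor A1 (Homo sapiens), read by scintillation counting, with a stated time of 90 min (on this read-out higher numbers stand for weaker inhibition and lower numbers for stronger inhibition), gives 12.5 nM. Compound 2 `Nc1nc(NCc2cccs2)nc2sc(-c3cccs3)nc12` gives 73 nM in this assay, and compound 3 `Nc1nc(NCc2cccnc2)nc2sc(-c3ccco3)nc12` gives 7.12 nM. Compound 2 stands with the highest number of the three: the step of a 5.8-fold higher number from compound 1 to compound 2 (0.77 log units; beyond the scatter) is beyond the scatter, and the gap to compound 3 is wider still. The next compound awaiting measurement is compound 4 `COc1ccccc1CNc1nc(N)c2nc(-c3cccs3)sc2n1`. Relative to compound 2 the change is 2-methoxyphenyl in place of thiophen-2-yl on a saturated chain carbon bound to a nitrogen on an aromatic ring. Going by the values given here, the only measured step at the same place is a 1.8-fold lower number from compound 1 to compound 3 (0.24 log units; within the scatter), which lies within the scatter; the step of a 5.8-fold higher number from compound 1 to compound 2 (0.77 log units; beyond the scatter) alters a different group and does not bear directly on this change. On that basis the step of a 1.2-fold lower number from compound 2 to compound 4 (0.09 log units; within the scatter) is expected to stay within the scatter, with no firm direction. Compound 4 is therefore estimated at 60 nM in this assay, with a range of 20 nM to 200 nM.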

Compound 4, inhibition constant: 17.3 nM
The estimate for compound 4 lay 3.5-fold (0.54 log units) above the measured number; measured number outside the range, below it.
By their numbers in this assay, from the lowest: compounds 3, 1 and 4 (each within the scatter of the next, the first and the last beyond it); then compound 2.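

Going by these compounds alone, on a saturated chain carbon bound to a nitrogen on an aromatic ring, the choice of group does register in this assay: the change to 2-methoxyphenyl gives a 4.2-fold lower number from compound 2 to compound 4 (0.63 log units; beyond the scatter), whereas the only earlier change at this place, a 1.8-fold lower number from compound 1 to compound 3 (0.24 log units; within the scatter), stayed within the scatter. This place therefore takes a six-membered aromatic ring of carbon only, carrying a methoxy group, with no loss and with a lower number, at least where thiophen-2-yl sits on the aromatic carbon. No measurement at hand accounts for this step.

The compounds shown do not separate the share of the phenyl ring from that of the methoxy group; a plain phenyl, or a hydroxy or dimethylamino group in place of methoxy, would bear on that. On these data alone, whether the same change holds with furan-2-yl on the aromatic carbon also remains open.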